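A Pyridyl for Chlorophenyl Swap Tested for Cytotoxicity

A few compounds are considered here, and "the series" means these few. Any claim that something is new, unique, unknown or untested is made for them only; others in the source may bear on it.

Compound 1, `COc1cccc(C(=O)Nc2ccc(NC(=O)c3cncnc3)cc2)c1`: in an ADME assay on MRC5 cells (Homo sapiens) for cytotoxicity (a lower number here means that less compound is tolerated, a higher number that more compound is tolerated), compound 1 gives only a limit, > 57000 nM.
Compound 2, `O=C(Nc1ccc(NC(=O)c2ccco2)cc1)c1cccc(Cl)c1`: in this assay compound 2 gives only a limit, > 57000 nM.
Compound 3, `COc1cccc(C(=O)Nc2ccc(NC(=O)c3ccco3)cc2)c1F`: in this assay compound 3 gives only a limit, > 57000 nM.

Compound 2 therefore stands where every measured value here stands, at the limit of > 57000 nM in this assay, at which 3 of the 3 values shown sit, and nothing in these numbers sets it apart from compound 1 or compound 3. Compound 4, `O=C(Nc1ccc(NC(=O)c2ccco2)cc1)c1cccnc1`, differs from compound 2 in one place: pyridin-3-yl in place of 3-chlorophenyl on a carbonyl carbon. Within the data shown here, no step between measured compounds is available to guide the expectation. The step that the limit leaves unreadable from compound 2 to compound 4 is expected to be none beyond the scatter. Compound 4 is estimated at 80000 nM, within 40000 nM to 160000 nM, most likely again reported only as a limit.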

Compound 4, half-maximal cytotoxic concentration: > 57000 nM
Compound 4: only a limit was reported; the forecaster's own chance of this, stated with the estimate: 85%; the middle value does not contradict the limit.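

In this assay, among these compounds, compound 2 and compound 4 each give only a limit, so no step between them can be read. The compounds shown leave open whether pyridin-3-yl in place of 3-chlorophenyl changes the tolerated concentration at all.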